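Methyl in place of phenyl on the sulfonyl sulfur

The source may report more compounds than this note shows. Statements on the series, on what has been measured and on what is new or still open speak of the compounds shown alone.

Measured compounds:
compound 1, `COc1cc2nc(Cl)nc(NS(=O)(=O)c3ccccc3)c2cc1OC`, 8.17 ug/mL
compound 2, `COc1cc2nc(N3CCCC3)nc(NS(=O)(=O)C3CC3)c2cc1OC`, 9.13 ug/mL
compound 3, `COc1cc2nc(N3CCCC3)nc(NS(=O)(=O)c3cccc(C(F)(F)F)c3)c2cc1OC`, 15.9 ug/mL

Of the compounds shown here, three sharing one core have been measured in a functional assay on THP-1 cells (Homo sapiens) for cytotoxicity, read by MTT assay, with a stated time of 24 h; a lower number here means a stronger inhibitor, a higher number a weaker inhibitor. Compound 1 shows the lowest of the three numbers, but its gap to compound 2 and to compound 3 stays within the scatter, so no order among them can be read. Among the compounds with values here, the one step that can be followed is a 1.7-fold higher number from compound 2 to compound 3 (0.24 log units; within the scatter), a swap of one sulfonyl substituent for another without a shift beyond the scatter.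

Compound 4, `COc1cc2nc(Cl)nc(NS(C)(=O)=O)c2cc1OC`, is not yet measured. It differs from compound 1 in one place: methyl in place of phenyl on a sulfonyl sulfur. This change, like the step from compound 2 to compound 3, replaces one sulfonyl substituent with another while the rest of the molecule stays unchanged. Since that step stayed within the scatter, no step beyond the scatter is expected from compound 1 to compound 4 either, and the estimate is a 1.1-fold lower number from compound 1 to compound 4 (0.04 log units; within the scatter). For compound 4 a value of 7.5 ug/mL is expected, within a range of 3.5 ug/mL to 16 ug/mL.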

Compound 4, half-maximal inhibitory concentration: 99.7 ug/mL
For compound 4 the middle estimate is 13-fold (1.12 log units) below the measured one; measured number above the stated range.
By their numbers in this assay, from the lowest: compounds 1, 2 and 3 (each within the scatter of the next); then compound 4.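

In this assay the substituent on a sulfonyl sulfur proves able to move the number well beyond the scatter: methyl in place of phenyl gives a 12-fold higher number from compound 1 to compound 4 (1.09 log units; beyond the scatter) on the core of compound 1. The earlier swap at this place gave a 1.7-fold higher number from compound 2 to compound 3 (0.24 log units; within the scatter) and showed no such shift, but there a ring stood on the sulfur on both sides of the change, whereas compound 4 carries no ring at this place. Nothing measured here bears on why methyl gives this step.

The compounds shown leave open whether an ethyl or a benzyl on the sulfonyl sulfur would stay with phenyl or go with methyl. They also leave open whether methyl would give a step of this size on the core of compound 2, where a pyrrolidine ring takes the place of the chlorine.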